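Cytotoxicity of hydrazone analogues: from compound 3 to compound 4

The compounds below may be only part of what the source reports. "The series", "measured", "known", "first", "only" and "open" are said of these compounds alone.

Measured compounds:
compound 1 `COc1cc(/C=N/NC(=O)CCN2CCN(c3ccnc4cc(Cl)ccc34)CC2)ccc1O`: 9400 nM
compound 2 `O=C(CCN1CCN(c2ccnc3cc(Cl)ccc23)CC1)N/N=C/c1c[nH]c2ccccc12`: 5700 nM
compound 3 `COc1cc(/C=N/NC(=O)CCN2CCN(c3ccnc4cc(Cl)ccc34)CC2)ccc1OC(C)C`: 8800 nM

All three were tested in an ADME assay on cells (Splenocyte, Mus musculus, strain BALB/c) for cytotoxicity, read by thymidine incorporation, with a stated time of 24 h; a higher number here means a weaker inhibitor, a lower number a stronger inhibitor. The three numbers lie close together: compound 3 differs from compound 1 by a 1.1-fold lower number from compound 1 to compound 3 (0.03 log units; within the scatter) and from compound 2 by a 1.5-fold higher number from compound 2 to compound 3 (0.19 log units; within the scatter), so no one of them can be called stronger or weaker than another on this evidence.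

Compound 4 `O=C(CCN1CCN(c2ccnc3cc(Cl)ccc23)CC1)N/N=C/c1cccc(Cl)c1` has not yet been measured in this assay. It differs from compound 3 in one place: 3-chlorophenyl in place of 4-isopropoxy-3-methoxyphenyl on a carbon with a double bond to nitrogen. Within the data shown here, the steps that bear on this change are those that also swap the group on that carbon, namely a 1.6-fold lower number from compound 1 to compound 2 (0.22 log units; within the scatter) and a 1.5-fold higher number from compound 2 to compound 3 (0.19 log units; within the scatter); the remaining step, a 1.1-fold lower number from compound 1 to compound 3 (0.03 log units; within the scatter), only alters the oxygen substituent. Every one of these changes to the aryl group left the number inside the scatter, so no step beyond the scatter is expected here either. Compound 4 is therefore expected to give about 8000 nM in this assay, with a range from 3500 nM to 18000 nM. That amounts to an expected step of a 1.1-fold lower number from compound 3 to compound 4 (0.04 log units; within the scatter).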

Compound 4, half-maximal inhibitory concentration: > 100000 nM
Compound 4: no number, only a limit; the forecaster's own chance of this, stated with the estimate: 5%; middle value at least 12-fold (1.09 log units) away from the limit.
By their numbers in this assay, from the lowest: compounds 2, 3 and 1 (each within the scatter of the next). At a limit, above all of these: compound 4.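

In this assay, the three earlier groups on the carbon with a double bond to nitrogen, 4-hydroxy-3-methoxyphenyl, 1H-indol-3-yl and 4-isopropoxy-3-methoxyphenyl, gave numbers within the scatter of one another, so the position looked insensitive to the group placed on it. 3-Chlorophenyl ends that picture, with an at least 11-fold higher number from compound 3 to compound 4 (1.05 log units; beyond the scatter), an at least 17-fold higher number from compound 2 to compound 4 (1.24 log units; beyond the scatter) and an at least 10-fold higher number from compound 1 to compound 4 (1.02 log units; beyond the scatter), which makes compound 4 the weakest inhibitor of the four. Compound 4 has only a limit, not a number: the limit of > 100000 nM in this assay, at which 1 of the 4 values shown sits.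

The compounds shown leave open whether the chlorine itself matters or whether the loss of the groups on the other rings is enough, and a plain phenyl would separate these two readings. They also leave open what an amine or a carboxylic acid would do in the place of that chlorine.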